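Moving the hydroxyl on the piperidine of compound 2

The compounds below may be only part of what the source reports. "The series", "measured", "known", "first", "only" and "open" are said of these compounds alone.

Measured so far:
compound 1 `CN(C)CCCCOc1ccc2oc(-c3ccccc3)cc(=O)c2c1`, 720 nM
compound 2 `O=c1cc(-c2ccccc2)oc2ccc(OCCCCCCN3CCC(O)CC3)cc12`, 100 nM

Among the measured compounds shown here, compound 2 gives the lowest number of the two in an assay on isolated protein (Cavia porcellus) with Sigma non-opioid intracellular receptor 1 (Homo sapiens) as the target, read by radioligand binding; on this read-out lower numbers stand for stronger inhibition and higher numbers for weaker inhibition; its only neighbour is compound 1, and the step of a 7.2-fold lower number from compound 1 to compound 2 (0.86 log units; beyond the scatter) separates them. Compound 3 `O=c1cc(-c2ccccc2)oc2ccc(OCCCCCCN3CCCC(O)C3)cc12` differs from compound 2 by 3-hydroxypiperidin-1-yl in place of 4-hydroxypiperidin-1-yl on a saturated chain carbon, six bonds along the chain from an oxygen on an aromatic ring. For the measured compounds named here, no measured step bears on this change: the single step recorded exchanges the whole amine and says nothing about where the hydroxyl sits on the ring. The step of a 1.3-fold higher number from compound 2 to compound 3 (0.11 log units; within the scatter) is therefore expected to stay within the scatter, in no fixed direction. Compound 3 is expected at 130 nM with a range from 50 nM to 350 nM.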

Compound 3, half-maximal inhibitory concentration: 86 nM
Compound 3: middle estimate off by 1.5-fold (0.18 log units), on the high side; the measured number falls inside the stated range.
By their numbers in this assay, from the lowest: compounds 3 and 2 (each within the scatter of the next); then compound 1.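

In this assay, the hydroxyl moves around the piperidine ring with a 1.2-fold lower number from compound 2 to compound 3 (0.07 log units; within the scatter), so the 3-hydroxypiperidin-1-yl and 4-hydroxypiperidin-1-yl groups cannot be told apart here. Placing 2-(3-hydroxypiperidin-1-yl)ethyl in place of dimethylamino gives an 8.4-fold lower number from compound 1 to compound 3 (0.92 log units; beyond the scatter), so the change seen earlier with the 4-hydroxy isomer also holds for the 3-hydroxy isomer. Nothing at hand explains either step. Open, as far as these compounds go, is whether the hydroxyl matters at all, which unsubstituted piperidin-1-yl would test. Also open, from the compounds shown here alone, is whether another ring amine, such as morpholine, fits at this chain end.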